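Adding a Methyl at Two Different Places on a Side Chain

The source may hold more compounds than are shown below. What is called first, only, known or untested is meant among the compounds shown, and "the series" means these compounds.

Compound 1, `COCC(COC)N(C)c1nc(C)nc2c1nnn2-c1ccc(C(C)C)cc1Br`, gives 21.3 nM in an in vitro assay on 293-EBNA cells for binding affinity to corticotropin-releasing factor receptor 1 (Homo sapiens); on this read-out lower numbers stand for stronger inhibition and higher numbers for weaker inhibition. Compound 2, `CCN(c1nc(C)nc2c1nnn2-c1ccc(C(C)C)cc1Br)C(COC)COC`, differs from compound 1 in one place: methyl in place of hydrogen on a saturated chain carbon bound to a nitrogen on an aromatic ring. In this assay compound 2 gives 123 nM, so this change made a 5.8-fold higher number from compound 1 to compound 2 (0.76 log units; beyond the scatter). Compound 3, `CCCC(CC)Nc1nc(C)nc2c1ncn2-c1ccc(C(C)C)cc1Br`, is built on a different core, and the difference between the two cores is not broken down here. In this assay compound 3 gives 4.4 nM, the lowest of the three numbers, with all steps to the others beyond the usual scatter.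

Compound 4, `CCCC(CCC)Nc1nc(C)nc2c1ncn2-c1ccc(C(C)C)cc1Br`, has not yet been measured. It differs from compound 3 by methyl in place of hydrogen on a saturated chain carbon, three bonds along the chain from a nitrogen on an aromatic ring. Within the data shown here, this is the same kind of change as the one from compound 1 to compound 2, but not the same: in the earlier pair the methyl entered on a saturated chain carbon bound to a nitrogen on an aromatic ring, whereas here it enters on a saturated chain carbon three bonds along the chain from a nitrogen on an aromatic ring, and on a different core. Among the measured compounds shown here, because the earlier step was a 5.8-fold higher number from compound 1 to compound 2 (0.76 log units; beyond the scatter), some weakening cannot be ruled out, yet the change sits further out along the chain, and only one pair shows the earlier effect. The step from compound 3 to compound 4 is therefore expected to be small, roughly a 1.3-fold higher number from compound 3 to compound 4 (0.10 log units; within the scatter). Compound 4 is expected to give about 5.5 nM in this assay, most likely between 2 nM and 15 nM.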

Compound 4, inhibition constant: 3.6 nM
For compound 4 the middle estimate is 1.5-fold (0.18 log units) above the measured one, within the range that was stated.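

In this assay the new step is a 1.2-fold lower number from compound 3 to compound 4 (0.09 log units; within the scatter), a difference that repeat measurements alone could produce, and it does not match the earlier step: the same change on two cores in this assay, a 5.8-fold higher number (0.76 log units; beyond the scatter) from compound 1 to compound 2 and a 1.2-fold lower number (0.09 log units; within the scatter) from compound 3 to compound 4, 7.1-fold (0.85 log units) apart, beyond the scatter of two such steps

For a newcomer's rule of thumb, this means that a methyl in place of a hydrogen cannot be assigned a single effect in this series, and the result seen on one core cannot simply be carried over to the other. It does not show that the core is what sets the two steps apart: the two pairs differ in the core, but also in where the methyl enters, on a saturated chain carbon bound to a nitrogen on an aromatic ring in one pair and three bonds along the chain from that nitrogen in the other, and each result rests on a single pair.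

The compounds shown leave open what the methyl does at each of these two places on the other core, which is the comparison that would separate core from place. They also leave open how a longer chain, such as a butyl group in place of one propyl, or a hydroxyl group on the chain would read on the core of compound 4.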